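A few compounds are considered here, and "the series" means these few. Any claim that something is new, unique, unknown or untested is made for them only; others in the source may bear on it.

Measured so far:
Compound 1 `O=C(NNC(=S)Nc1ccccc1[N+](=O)[O-])c1ccncc1` — > 300000 nM
Compound 2 `CCOc1ccc(NC(=S)NNC(=O)c2ccncc2)cc1` — > 300000 nM
Compound 3 `O=C(NNC(=S)Nc1ccc(S(=O)(=O)Nc2ncccn2)cc1)c1ccncc1` — > 300000 nM

In an ADME assay on MCF-10A cells (Homo sapiens) for cytotoxicity, read by WST assay, with a stated time of 48 h (a lower number here means a stronger inhibitor, a higher number a weaker inhibitor), compound 1 gives > 300000 nM, which is a limit of the assay and not a number. Compound 2 gives > 300000 nM in this assay, again only a limit. Compound 3 gives > 300000 nM, likewise a limit. Compound 2 therefore stands where the whole set stands, at the limit of > 300000 nM in this assay, at which 3 of the 3 values shown sit, and no order among the three can be read from these values.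

Compound 4 `COc1ccc(NC(=S)NNC(=O)c2ccncc2)cc1` is still to be measured in this assay. It differs from compound 2 by hydrogen in place of methyl on a saturated chain carbon bound to an oxygen on an aromatic ring. Among the compounds with values here, no measured step exists for this change; no movement beyond the usual scatter is expected, and a further limit seems the likely outcome. The step from compound 2 to compound 4 is estimated at a number no higher from compound 2 to compound 4 (the limit leaves the size open). Compound 4 is expected near 300000 nM, within 150000 nM to 1000000 nM.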

Compound 4, half-maximal inhibitory concentration: 47500 nM
Estimate against measurement, compound 4: 6.3-fold (0.80 log units) above; measured number outside the range, below it.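

In this assay, hydrogen in place of methyl on a saturated chain carbon bound to an oxygen on an aromatic ring gives an at least 6.3-fold lower number from compound 2 to compound 4 (0.80 log units; beyond the scatter). This is the first measured step in the series, so the ethoxy to methoxy change is shown to move the read-out beyond the scatter. Compound 4 alone carries a number, and the true size of the step stays open, as the others remain at a limit: the limit of > 300000 nM in this assay, at which 3 of the 4 values shown sit.

Open, as far as these compounds go, is how a hydroxyl or a propoxy group in place of the methoxy group would read. Also open, from the compounds shown here alone, is whether the same change would have any effect in another substitution setting.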